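A Dichlorophenyl-to-Dimethylphenyl Swap and Cytotoxicity

This account rests on a few compounds, and the source may have more. Where it says the series, first, only, none or still open, it means among the compounds named here.

Three compounds were tested in a functional assay on A375P cells (Homo sapiens) for cytotoxicity, read by MTT assay, with a stated time of 2 days; a lower number here means a stronger inhibitor, a higher number a weaker inhibitor. Compound 1 `Cc1cccc(N2CCN(CCCNc3nc(NCc4ccco4)c4ccccc4n3)CC2)c1C` gives 3040 nM, compound 3 `Clc1cccc(N2CCN(CCCNc3nc(NCc4ccco4)c4ccccc4n3)CC2)c1Cl` gives 3360 nM, and compound 2 `Fc1ccc2nc(NCCCCN3CCN(c4cccc(Cl)c4Cl)CC3)nc(NCc3ccco3)c2c1` gives 2650 nM; all three values lie within the scatter of one another. The change from compound 3 to compound 1 is 2,3-dimethylphenyl in place of 2,3-dichlorophenyl on an amine nitrogen in a ring, and it moved a 1.1-fold lower number from compound 3 to compound 1 (0.04 log units; within the scatter). How the core of compound 2 differs from that of compound 3 is not broken down here. Compound 4 `Cc1cccc(N2CCN(CCCCNc3nc(NCc4ccco4)c4cc(F)ccc4n3)CC2)c1C` has not yet been measured; it carries the same change relative to compound 2, namely (2,3-dimethylphenyl in place of 2,3-dichlorophenyl on an amine nitrogen in a ring). Because the earlier step of a 1.1-fold lower number from compound 3 to compound 1 (0.04 log units; within the scatter) stayed within the scatter, the step from compound 2 to compound 4 in this assay is expected to be about a 1.1-fold lower number from compound 2 to compound 4 (0.03 log units; within the scatter). Compound 4 is estimated at 2500 nM, with a likely range from 1300 nM to 5000 nM.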

Compound 4, half-maximal inhibitory concentration: 3280 nM
Compound 4: the middle estimate sits 1.3-fold (0.12 log units) below what was measured; measured number inside the range.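

In this assay, placing 2,3-dimethylphenyl where 2,3-dichlorophenyl stood gave a 1.2-fold higher number from compound 2 to compound 4 (0.09 log units; within the scatter). The swap behaves alike on the two cores as far as can be told: the same change on two cores in this assay, a 1.1-fold lower number (0.04 log units; within the scatter) from compound 3 to compound 1 and a 1.2-fold higher number (0.09 log units; within the scatter) from compound 2 to compound 4, 1.4-fold (0.14 log units) apart, within the scatter of two such steps. Going by these compounds alone, this shows only that neither core gave a step beyond the scatter; it does not show that the change has any effect on cytotoxicity, and two pairs say nothing about other cores.

The compounds shown leave open whether another group on the same ring nitrogen, such as plain phenyl or a pyridyl ring, would shift the number beyond the scatter. Also open, going by these compounds, is what the fluorine and the chain length each contribute alone; the cores of compound 2 and compound 3 differ in both.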